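From allyl to 4-methoxybenzyl on the sulfur chain

A few compounds are considered here, and "the series" means these few. Any claim that something is new, unique, unknown or untested is made for them only; others in the source may bear on it.

Measured in an ADME assay on GES1 cells (Homo sapiens) for inhibition, read by MTT assay, with a stated time of 72 h (a higher number here means a weaker inhibitor, a lower number a stronger inhibitor), so far:
- compound 1 `Cc1cc(Nc2cc(-c3ccccc3)[nH]n2)n2nc(SCCc3ccccc3)nc2n1` gives 37400 nM
- compound 2 `C#CCSc1nc2nc(C)cc(Nc3cc(-c4ccccc4)[nH]n3)n2n1` gives 45700 nM
- compound 3 `C=CCSc1nc2nc(C)cc(Nc3cc(-c4ccccc4)[nH]n3)n2n1` gives > 50000 nM as a limit

Where compound 3 stands is given only by the limit of > 50000 nM in this assay, at which 1 of the 3 values shown sits, and not by a number of its own. The change to compound 4 `COc1ccc(CSc2nc3nc(C)cc(Nc4cc(-c5ccccc5)[nH]n4)n3n2)cc1` is 4-methoxyphenyl in place of vinyl on a saturated chain carbon bound to a sulfur and it places a six-membered aromatic ring of carbon only on the chain. Compound 1 is the measured compound that also carries a benzyl group there, so the nearest evidence is an at least 1.3-fold higher number from compound 1 to compound 3 (0.12 log units; that floor lies within the scatter) and it runs from benzyl to vinyl. Its size is only a floor. The other two steps are a 1.2-fold higher number from compound 1 to compound 2 (0.09 log units; within the scatter) and an at least 1.0-fold higher number from compound 2 to compound 3 (0.03 log units; that floor lies within the scatter) and neither shows a change beyond the scatter. On these steps, no step beyond the scatter is expected in this assay for the new group. The estimated step is an at least 1.3-fold lower number from compound 3 to compound 4 (0.11 log units; that floor lies within the scatter) and nothing larger is anticipated. The reading may well be another limit. A number would be expected near that of compound 1 at 37400 nM in the same assay. In this assay the estimate for compound 4 is 38000 nM (expected range 18000 nM to 60000 nM).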

Compound 4, half-maximal inhibitory concentration: 28200 nM
For compound 4 the middle estimate is 1.3-fold (0.13 log units) above the measured one; the range from low to high includes it.
By their numbers in this assay, from the lowest: compounds 4, 1 and 2 (each within the scatter of the next). At a limit, above all of these: compound 3.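

In this assay, compound 4 brings a 4-methoxyphenyl group onto the saturated chain carbon bound to a sulfur, and with it the first hydrogen-bond acceptor in this part of the molecule, yet a 1.3-fold lower number from compound 1 to compound 4 (0.12 log units; within the scatter) stays within the scatter. The much smaller ethynyl group gives the same picture: a 1.6-fold lower number from compound 2 to compound 4 (0.21 log units; within the scatter) also stays within the scatter, so the compounds with numbers of their own show no step beyond the scatter at this position, even though the group entering here counts 8 heavy atoms. The comparison with the vinyl group, an at least 1.7-fold lower number from compound 3 to compound 4 (0.24 log units; that floor lies within the scatter), gives only a floor, and compound 3 remains a limit and not a number: the limit of > 50000 nM in this assay, at which 1 of the 4 values shown sits.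

From the compounds shown here alone, it remains open whether any group at this position can move the number beyond the scatter, for instance an amine, a carboxylic acid or a longer chain ending in 4-methoxyphenyl. Going by these compounds, it also remains open what a plain phenyl on the same chain carbon would give, so the part played by the methoxy group itself cannot be told from the part played by the ring.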